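Replacing an Amide Tail with a Chlorophenyl Ring

The source may hold more compounds than are shown below. What is called first, only, known or untested is meant among the compounds shown, and "the series" means these compounds.

Compound 1 `CNC(=O)c1cncc(NS(=O)(=O)c2cc(Cl)ccc2OC)c1` and compound 2 `CCNC(=O)c1cncc(NS(=O)(=O)c2cc(Cl)ccc2OC)c1` share one core and differ only in the group on the amide-type nitrogen. In an assay on isolated protein for inhibition of alkaline phosphatase, tissue-nonspecific isozyme (Homo sapiens) (on this read-out lower numbers stand for stronger inhibition and higher numbers for weaker inhibition), compound 1 gives 109 nM. In this assay compound 2 gives 193 nM, and the step of a 1.8-fold higher number from compound 1 to compound 2 (0.25 log units; within the scatter) lies within the scatter, so the two compounds cannot be told apart by this measurement; compound 2 simply sits among two numbers that agree. Compound 3 `COc1ccc(Cl)cc1S(=O)(=O)Nc1cncc(-c2ccc(Cl)cc2)c1` carries a far larger change: 4-chlorophenyl in place of ethylcarbamoyl on an aromatic carbon. The whole ethylcarbamoyl tail leaves and a 4-chlorophenyl ring enters. For the measured compounds named here, the only measured step swaps methyl for hydrogen on the amide-type nitrogen and says nothing about removing that tail altogether, so no measured step bears on this change and its direction stays open. For compound 3 the expected result in this assay is 250 nM, spanning 50 nM to 1500 nM. That expectation amounts to an estimated step of a 1.3-fold higher number from compound 2 to compound 3 (0.11 log units; within the scatter), with no direction claimed beyond the scatter.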

Compound 3, half-maximal inhibitory concentration: 198 nM
Compound 3: the middle estimate sits 1.3-fold (0.10 log units) above what was measured, within the range that was stated.
By their numbers in this assay, from the lowest: compounds 1, 2 and 3 (each within the scatter of the next).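

In this assay, the step of a 1.0-fold higher number from compound 2 to compound 3 (0.01 log units; within the scatter) shows that a whole change of group at this aromatic carbon, from ethylcarbamoyl to 4-chlorophenyl, leaves no readable difference. The step of a 1.8-fold higher number from compound 1 to compound 3 (0.26 log units; within the scatter) gives the same reading against the methyl amide. The tail that leaves carries a hydrogen-bond donor and acceptor and the ring that enters carries neither, yet the numbers still agree, so in these compounds the amide is not needed for inhibition in this range, and no measurement available here explains that agreement.

The compounds shown leave open whether the ring's chlorine matters, which plain phenyl in the same place would test. They also cannot say how much this position tolerates in general, which an amine, a carboxylic acid or a longer chain there would help to settle.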